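A dichlorophenyl swap on the shared core

The source may report more compounds than this note shows. Statements on the series, on what has been measured and on what is new or still open speak of the compounds shown alone.

Measured in an ADME assay on U-937 cells (Homo sapiens) for cytotoxicity, read by MTT assay, with a stated time of 24 h; a higher number here means that more compound is tolerated, a lower number that less compound is tolerated:
- compound 1 `Cc1ccc(OC(CCn2ccnc2)c2ccc(Cl)cc2)cc1`: 325000 nM
- compound 2 `Clc1ccc(C(CCn2ccnc2)Oc2c(Cl)cccc2Cl)cc1`: 271000 nM

Compound 2 stands level with compound 1 in this assay, as their two values lie within the scatter of each other. Compound 3 `Clc1ccc(C(CCn2ccnc2)Oc2cc(Cl)cc(Cl)c2)cc1` has not yet been measured. It differs from compound 2 as follows: 3,5-dichlorophenyl in place of 2,6-dichlorophenyl on an oxygen on a saturated carbon. The two have the same atoms, joined differently. For the measured compounds named here, only one measured step bears on this change, at the same place on the shared core. That step, a 1.2-fold lower number from compound 1 to compound 2 (0.08 log units; within the scatter), brought in the 2,6-dichlorophenyl in place of 4-methylphenyl. Going by the values given here, no measured pair shows the effect of exchanging 2,6-dichlorophenyl for 3,5-dichlorophenyl, so the evidence is thin and no direction can be favoured. The expected change is a 1.1-fold lower number from compound 2 to compound 3 (0.04 log units; within the scatter), which is nothing beyond the scatter. For compound 3 the estimated value is 250000 nM, with an expected range of 110000 nM to 450000 nM.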

Compound 3, half-maximal cytotoxic concentration: 180000 nM
Compound 3: the middle estimate sits 1.4-fold (0.14 log units) above what was measured; measured number inside the range.
By their numbers in this assay, from the lowest: compounds 3, 2 and 1 (each within the scatter of the next).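

Measured in this assay, the exchange of 2,6-dichlorophenyl for 3,5-dichlorophenyl gives a 1.5-fold lower number from compound 2 to compound 3 (0.18 log units; within the scatter) and so shows that rearranging the same atoms at this place, on an oxygen on a saturated carbon, leaves the two compounds level. Against the 4-methylphenyl group, the 3,5-dichlorophenyl group gives a 1.8-fold lower number from compound 1 to compound 3 (0.26 log units; within the scatter) and so compound 1, compound 2 and compound 3 can all be read as one level group, with no aryl group here yet separated from another. Nothing measured here offers an explanation for these readings. Going by these compounds, whether an amine or a carboxylic acid on this aromatic ring would move the number beyond the scatter remains open. So does the effect of a longer chain in place of the aromatic ring on the oxygen.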